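The source may report more compounds than this note shows. Statements on the series, on what has been measured and on what is new or still open speak of the compounds shown alone.

Compound 2 `N#C[C@@H]1C[C@H]1CN([C@H](CCC(F)(F)F)C(N)=O)S(=O)(=O)c1ccc(Cl)cc1` sits at the low end of the two numbers gathered so far: in an ADME assay on MDCKII-LE cells (Canis lupus familiaris) for permeability (a lower number here means that the compound crosses the layer more slowly, a higher number that the compound crosses the layer faster), compound 2 gives 9.94 10^-6 cm/s. For the measured compounds named here, the only other measured compound is compound 1 `NC(=O)[C@@H](CCC(F)(F)F)N(CC12CC(c3ncon3)(C1)C2)S(=O)(=O)c1ccc(Cl)cc1`, which in this assay gives 19.3 10^-6 cm/s; the one measured step, a 1.9-fold lower number from compound 1 to compound 2 (0.29 log units; within the scatter), is a swap of a larger group for a smaller one and lies within the scatter, so it says little about ordering.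

Compound 3 `N#CC1(CN([C@H](CCC(F)(F)F)C(N)=O)S(=O)(=O)c2ccc(Cl)cc2)CC1` keeps the same atoms as compound 2 but joins them differently: 1-cyanocyclopropyl in place of 2-cyanocyclopropyl on a saturated chain carbon bound to a sulfonamide nitrogen. Going by the values given here, no measured step touches this kind of rearrangement, since the step from compound 1 to compound 2 changed which group is present rather than how the nitrile sits on the ring. With only that small, within-scatter step to lean on, no movement beyond the scatter is expected in this assay. Compound 3 is therefore estimated at 10 10^-6 cm/s, between 5 10^-6 cm/s and 20 10^-6 cm/s, a step of a 1.0-fold higher number from compound 2 to compound 3 (0.00 log units; within the scatter).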

Compound 3, apparent permeability: 29.9 10^-6 cm/s
Beside the measured number, compound 3's estimate is 3.0-fold (0.48 log units) below it; the measured number lies above the stated range.
By their numbers in this assay, from the lowest: compounds 2, 1 and 3 (each within the scatter of the next, the first and the last beyond it).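

In this assay, for the compounds shown here, the place of the nitrile on the cyclopropyl ring proves to matter: 1-cyanocyclopropyl in place of 2-cyanocyclopropyl, with the same atoms in both groups, gives a 3.0-fold higher number from compound 2 to compound 3 (0.48 log units; beyond the scatter) and is the first step here to pass beyond the scatter. By contrast, the much larger change in group size gives a 1.5-fold higher number from compound 1 to compound 3 (0.19 log units; within the scatter) and stays within the scatter, so at this place how the atoms are joined can count for more than how many there are. Nothing available explains why the rearrangement has this effect.

The step also removes the 2 defined stereocentres of the leaving group, so the nitrile's place cannot be told apart from their loss. As far as these compounds go, what a 1-cyanocyclobutyl group or a plain cyclopropyl group would give at this place remains open.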